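The source may hold more compounds than are shown below. What is called first, only, known or untested is meant among the compounds shown, and "the series" means these compounds.

Compound 3 `C[C@@H]1CN(C(=O)c2nc(Nc3cc(C4CC4)[nH]n3)c3cc(Cl)ccc3n2)CCN1C(=O)OC(C)(C)C` stands highest of the three measured compounds in an ADME assay on S9 fraction from liver (Rattus norvegicus), read by LC-MS, with a stated time of 60 min, at 37 degrees C (on this read-out higher numbers stand for a more stable compound and lower numbers for a less stable compound), where compound 3 gives 71.3%. Compound 1 `CC(C)COC(=O)N1CCN(C(=O)c2nc(Nc3cc(C4CC4)[nH]n3)c3cc(Cl)ccc3n2)C[C@H]1C` gives 61.1%, and compound 2 `CC(C)C(=O)OCOC(=O)N1CCN(C(=O)c2nc(Nc3cc(C4CC4)[nH]n3)c3cc(Cl)ccc3n2)C[C@H]1C` gives 14%. Compound 4 `CC(OC(=O)N1CCN(C(=O)c2nc(Nc3cc(C4CC4)[nH]n3)c3cc(Cl)ccc3n2)C[C@H]1C)OC(=O)C(C)(C)C` has not yet been measured; it differs from compound 3 by 1-(((tert-butyl)carbonyl)oxy)ethyl in place of tert-butyl on an oxygen next to a carbonyl group. Among the measured compounds shown here, two measured steps bear on this change. Going from isopropyl to ((isopropylcarbonyl)oxy)methyl on an oxygen next to a carbonyl group cost a number 47.1 percentage points lower from compound 1 to compound 2 (beyond the scatter), and returning to tert-butyl regained a number 57.3 percentage points higher from compound 2 to compound 3 (beyond the scatter). Since compound 4 again carries a chain of this kind on that oxygen, a large fall is expected, a number 51.3 percentage points lower from compound 3 to compound 4 (beyond the scatter), because compound 2 showed 14%. Compound 4 is therefore estimated to give 20%, within a range from 5% to 45%.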

Compound 4, percent of the compound remaining: 66.3%
Compound 4: the middle estimate sits 46.3 percentage points below what was measured; the measured number lies above the stated range.
By their numbers in this assay, from the lowest: compound 2; then compounds 1, 4 and 3 (each within the scatter of the next, the first and the last beyond it).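

In this assay a chain holding a second carbonyl on this oxygen need not mean a low number: a number 5 percentage points lower from compound 3 to compound 4 (within the scatter) and a number 5.2 percentage points higher from compound 1 to compound 4 (within the scatter) put 1-(((tert-butyl)carbonyl)oxy)ethyl level with tert-butyl and isobutyl. The two carbonyl-bearing chains themselves part widely, with a number 52.3 percentage points higher from compound 2 to compound 4 (beyond the scatter) in favour of this chain over ((isopropylcarbonyl)oxy)methyl. Nothing at hand explains that gap. On these data alone, these two chains differ in both the extra methyl and the tert-butyl end, so which of these matters stays open. A 1-((isopropylcarbonyl)oxy)ethyl or a (((tert-butyl)carbonyl)oxy)methyl chain would separate them.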